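Swapping an Amino Ester for Dipropylamino in a Toxicity Test

The compounds below may be only part of what the source reports. "The series", "measured", "known", "first", "only" and "open" are said of these compounds alone.

Three related compounds have been tested so far in an ADME assay on NIH3T3 cells (Mus musculus) for cytotoxicity (on this read-out higher numbers stand for lower toxicity in this test and lower numbers for higher toxicity in this test), and only one of them gives an exact number. In this assay compound 1 (`CC(C)(C)OC(=O)N1CCN(CC#Cc2cc3ncnc(Nc4ccc(OCc5cccc(F)c5)c(Cl)c4)c3s2)CC1`) gives 47 uM as its measured result. Compound 2 (`CC(C)(C)OC(=O)N1CCC[C@H]1C#Cc1cc2ncnc(Nc3ccc(OCc4cccc(F)c4)c(Cl)c3)c2s1`) reads > 100 uM and this is a limit of the assay, not a number. Compound 3 (`CCOC(=O)CN(C)CC#Cc1cc2c(Nc3ccc(OCc4cccc(F)c4)c(Cl)c3)ncnc2s1`) reads > 50 uM and this is also a limit, so its standing is known only as that limit.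

The next compound to be measured is compound 4 (`CCCN(CC#Cc1cc2c(Nc3ccc(OCc4cccc(F)c4)c(Cl)c3)ncnc2s1)CCC`). It carries dipropylamino in place of ((ethoxycarbonyl)methyl)(methyl)amino on a saturated chain carbon bound to a triple-bonded carbon. For the measured compounds named here, no two tested compounds differ in just one place, so this swap has no direct precedent here. A modest move towards a lower number in this assay is expected, though a change no larger than the usual scatter remains possible. That expectation rests on compound 1, whose 47 uM shows that a close relative can give a number rather than a limit. The estimated step of an at least 1.6-fold lower number from compound 3 to compound 4 (0.22 log units; that floor lies within the scatter) is therefore rough. In this assay the estimated value for compound 4 is 30 uM with an expected range from 10 uM to 90 uM on this read-out.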

Compound 4, half-maximal toxic concentration: 2.2 uM
The estimate for compound 4 lay 14-fold (1.13 log units) above the measured number; measured number below the stated range.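

Dipropylamino in place of ((ethoxycarbonyl)methyl)(methyl)amino gives an at least 22-fold lower number from compound 3 to compound 4 (1.35 log units; beyond the scatter) in this assay, so the group on this saturated chain carbon bound to a triple-bonded carbon can shift the read-out well beyond the usual scatter. For the compounds shown here, this is the first pair here that differs in just one place, and so the first direct reading of what a change at this position can do. Compound 3 has a limit and not a number, so the printed step is a floor and the real step could be larger: the limit of > 50 uM in this assay, at which 1 of the 4 values shown sits.

A single swap cannot separate the parts of the change, since the ester-bearing arm leaves, the methyl leaves and two propyl chains enter all at once, so it remains unclear which of these matters for the lower number. A smaller dimethylamino group, a longer chain such as dibutylamino, or a carboxylic acid in place of the ethyl ester at this same place could help to pull these parts apart.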